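The compounds below may be only part of what the source reports. "The series", "measured", "known", "first", "only" and "open" are said of these compounds alone.

Compound 1 `Cc1cc(Nc2nc(NCc3ccc(F)cc3F)nc3ccc(F)cc23)n[nH]1` and compound 2 `Fc1ccc(CNc2nc(Nc3cc(C4CC4)[nH]n3)c3cc(F)ccc3n2)c(F)c1` share one core. In an assay for inhibition of high affinity nerve growth factor receptor (Homo sapiens), read by HTRF, with a stated time of 30 min, in the presence of a further agent that is not named here (a lower number here means a stronger inhibitor, a higher number a weaker inhibitor), compound 1 gives 44 nM, and compound 2 gives 59 nM. The change between them, (cyclopropyl in place of methyl on an aromatic carbon), made a step of a 1.3-fold higher number from compound 1 to compound 2 (0.13 log units; within the scatter). Compound 3 `Cc1cc(Nc2nc(NCc3ccc(F)cc3F)nc3cc(Cl)ccc23)n[nH]1` carries a different core; how that core differs from the core of compound 1 is not broken down here. In this assay compound 3 gives 15 nM, the lowest of the three numbers. Compound 4 `Fc1ccc(CNc2nc(Nc3cc(C4CC4)[nH]n3)c3ccc(Cl)cc3n2)c(F)c1` is not yet measured; it differs from compound 3 by cyclopropyl in place of methyl on an aromatic carbon, the same change seen between compound 1 and compound 2. For compound 4 the expected step is a 1.3-fold higher number from compound 3 to compound 4 (0.10 log units; within the scatter), because the same change earlier gave a 1.3-fold higher number from compound 1 to compound 2 (0.13 log units; within the scatter). Compound 4 is therefore expected to give about 19 nM in this assay, estimated to lie between 9 nM and 40 nM.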

Compound 4, half-maximal inhibitory concentration: 290 nM
The estimate for compound 4 lay 15-fold (1.18 log units) below the measured number; measured number outside the range, above it.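

In this assay, cyclopropyl in place of methyl gave a 19-fold higher number from compound 3 to compound 4 (1.29 log units; beyond the scatter), a large loss of strength on the core of compound 3. The size of this step did not carry over from one core to the other: the same change on two cores in this assay, a 1.3-fold higher number (0.13 log units; within the scatter) from compound 1 to compound 2 and a 19-fold higher number (1.29 log units; beyond the scatter) from compound 3 to compound 4, 14-fold (1.16 log units) apart, beyond the scatter of two such steps This shows that the effect of the change depends on the core, but two pairs cannot show which feature of the core is responsible or how the change would behave on a further core.

The compounds shown leave open whether an ethyl or isopropyl group on the same aromatic carbon would behave more like methyl or like cyclopropyl on each core. They also leave open whether a third core would follow either pair.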